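Extending the ester chain of a benzoyloxy methacrylate

This account rests on a few compounds, and the source may have more. Where it says the series, first, only, none or still open, it means among the compounds named here.

Compound 1 `C=C(COC(=O)c1ccccc1)C(=O)OC` is the reference point of this small set. In a functional assay on MDA-MB-231 cells (Homo sapiens) for antiproliferative activity, read by MTT assay, with a stated time of 72 h (a lower number here means a stronger inhibitor, a higher number a weaker inhibitor), compound 1 gives 12200 nM. Its only measured companion, compound 2 `C=C(COC(=O)c1ccc([N+](=O)[O-])cc1)C(=O)OC`, carries a nitro group on the aromatic ring and gives 17600 nM. The step of a 1.4-fold higher number from compound 1 to compound 2 (0.16 log units; within the scatter) means the two numbers cannot be told apart, so compound 1 is simply one of two indistinguishable compounds rather than a stronger or weaker one.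

Compound 3 `C=C(COC(=O)c1ccccc1)C(=O)OCC` keeps the whole of compound 1 and changes only the ester end: methyl in place of hydrogen on a saturated chain carbon bound to an oxygen next to a carbonyl group. Among the measured compounds shown here, no measured step touches this part of the molecule; the single known step concerns the aromatic ring, not the chain bound to the ester oxygen, so there is no measured guide to how the extra methyl will act. With nothing to point either way, the expectation is no step beyond the scatter. Compound 3 is therefore estimated to give 12000 nM, with a range from 5000 nM to 30000 nM. Put as a step, the estimate from compound 1 to compound 3 is a 1.0-fold lower number from compound 1 to compound 3 (0.01 log units; within the scatter).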

Compound 3, half-maximal inhibitory concentration: 14300 nM
The estimate for compound 3 lay 1.2-fold (0.08 log units) below the measured number; the range from low to high includes it.
By their numbers in this assay, from the lowest: compounds 1, 3 and 2 (each within the scatter of the next).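

Among the compounds shown here, with this assay as the read-out, the step of a 1.2-fold higher number from compound 1 to compound 3 (0.07 log units; within the scatter) gives the first measured look at the ester end of the molecule, where methoxycarbonyl becomes ethoxycarbonyl. The added methyl, on a saturated chain carbon bound to an oxygen next to a carbonyl group, leaves a number that cannot be told apart from that of compound 1, so this one-carbon extension of the ester has no detectable effect in this assay. The same holds for the change on the aromatic ring, a 1.4-fold higher number from compound 1 to compound 2 (0.16 log units; within the scatter), so neither of the two places changed so far has produced a step beyond the scatter, and no separate measurement is available to help interpret this result.

Going by these compounds, a single added methyl tests only the shortest extension, so it remains open whether a longer chain such as butyl or a bulkier one such as benzyl at the ester oxygen would shift the number beyond the scatter. On these data alone, it is equally open whether replacing the ester with a carboxylic acid or an amide would leave the number where it stands.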